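The source may report more compounds than this note shows. Statements on the series, on what has been measured and on what is new or still open speak of the compounds shown alone.

In a functional assay on cells (Cancer cell lines, Homo sapiens) for cytotoxicity, with a stated time of 48 h (on this read-out lower numbers stand for stronger inhibition of growth and higher numbers for weaker inhibition of growth), compound 1 `COc1cc2c(/C=C3/C(=O)Nc4ccc(O)cc43)c(Cl)n(Cc3cc(OC)c(OC)c(OC)c3)c2cc1C` gives 2340 nM, the lower of the two numbers measured here. Compound 2 `O=C1Nc2ccccc2/C1=C\c1c(Cl)n(Cc2ccccc2)c2ccccc12` gives 20900 nM, a clearly weaker result that lies beyond the usual scatter. Compound 3 `COc1cc2c(/C=C3/C(=O)Nc4ccc(Cl)cc43)c(Cl)n(Cc3cc(OC)c(OC)c(OC)c3)c2cc1C` has not yet been measured; it differs from compound 1 by chloro in place of hydroxy on an aromatic carbon. For the measured compounds named here, no measured pair here shows how such a change shifts this assay, so the expectation rests on compound 1 alone. The step from compound 1 to compound 3 is expected to be small, a 1.3-fold higher number from compound 1 to compound 3 (0.11 log units; within the scatter), not clearly beyond the scatter. Compound 3 is therefore estimated at 3000 nM, with a likely range from 1000 nM to 9000 nM.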

Compound 3, concentration for 50% growth inhibition: 3720 nM
Compound 3: middle estimate off by 1.2-fold (0.09 log units), on the low side; measured number inside the range.
By their numbers in this assay, from the lowest: compounds 1 and 3 (each within the scatter of the next); then compound 2.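

In this assay, putting chloro in place of hydroxy on this aromatic carbon gives a 1.6-fold higher number from compound 1 to compound 3 (0.20 log units; within the scatter) and so no clear difference. For this pair, then, the read-out does not depend on keeping the hydroxy, even though the chloro brings no hydrogen-bond donor. Nothing measured here explains why the number stays within the scatter. From the compounds shown here alone, whether an amine, a methoxy group or a carboxylic acid on this carbon would also leave the number within the scatter remains open. So does the result with only hydrogen there.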